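Moving the methoxy group on the amide-bound phenyl ring

The source may hold more compounds than are shown below. What is called first, only, known or untested is meant among the compounds shown, and "the series" means these compounds.

Within the data shown here, compound 3 `COc1cccc(C(=O)N(C)c2cccc3ccc(NS(=O)(=O)c4cc(-c5cccc(C(=O)N(C)C)c5)ccc4OC)cc23)c1` is the one compound of this set that gives a number in a functional assay on CHO cells for agonist activity at Orexin/Hypocretin receptor type 1 (Homo sapiens); a higher number here means that more compound is needed for the effect, a lower number that less compound is needed: compound 3 gives 232 nM. Compound 1 `COc1ccc(-c2cccc(C(=O)N(C)C)c2)cc1S(=O)(=O)Nc1ccc2cccc(NC(=O)c3ccccc3)c2c1` reaches only the limit of this assay, at > 10000 nM. Compound 2 `COc1ccccc1C(=O)N(C)c1cccc2ccc(NS(=O)(=O)c3cc(-c4cccc(C(=O)N(C)C)c4)ccc3OC)cc12` likewise stops at the limit, at > 10000 nM. Both limits sit at the same point (the limit of > 10000 nM in this assay, at which 2 of the 3 values shown sit), so the step that the two limits leave unreadable from compound 1 to compound 2 cannot be read. The other two steps are clear and large: an at least 43-fold lower number from compound 1 to compound 3 (1.63 log units; beyond the scatter) and an at least 43-fold lower number from compound 2 to compound 3 (1.63 log units; beyond the scatter). Within these three compounds, then, the placement of the methoxy group on the phenyl ring attached to the carbonyl carbon decides whether a number appears at all.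

Compound 4 `COc1ccc(C(=O)N(C)c2cccc3ccc(NS(=O)(=O)c4cc(-c5cccc(C(=O)N(C)C)c5)ccc4OC)cc23)cc1` continues this variation: 4-methoxyphenyl in place of 3-methoxyphenyl on a carbonyl carbon. Among the measured compounds shown here, the only guide is the step from compound 2 to compound 3, which shows that shifting the methoxy group changes the outcome by a large amount, though in which direction a further shift will act cannot be read from two points. A weakening seems at least as likely as a gain, and the chance of landing at the limit is real. For compound 4 the expected value in this assay is 1500 nM, within a range of 200 nM to 10000 nM, which corresponds to an estimated step of a 6.5-fold higher number from compound 3 to compound 4 (0.81 log units; beyond the scatter).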

Compound 4, half-maximal effective concentration: 654 nM
Beside the measured number, compound 4's estimate is 2.3-fold (0.36 log units) above it, within the range that was stated.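

Compound 4 also gives a number in this assay, so a measurable value at this carbonyl carbon is not tied to the 3-methoxyphenyl group alone. Moving the methoxy group to give the 4-methoxyphenyl group has a much smaller effect than the change from the 2-methoxyphenyl group: the first move gives a 2.8-fold higher number from compound 3 to compound 4 (0.45 log units; beyond the scatter), and the second gives an at least 15-fold lower number from compound 2 to compound 4 (1.18 log units; beyond the scatter). Replacing the benzamido group gives an at least 15-fold lower number from compound 1 to compound 4 (1.18 log units; beyond the scatter), and this and the step from the 2-methoxyphenyl group both start from a limit, so each shows only a minimum size: the limit of > 10000 nM in this assay, at which 2 of the 4 values shown sit.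

The compounds shown leave open how much the methoxy group itself contributes, since the only ring without it sits in the benzamido group of compound 1, which also has no methyl on the amide nitrogen. They also leave open how a 3,4-dimethoxyphenyl group, or an ethoxy group, a fluorine atom or a dimethylamino group in place of the methoxy group, would behave on this ring.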